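Changing the amide tail of compound 3

A few compounds are considered here, and "the series" means these few. Any claim that something is new, unique, unknown or untested is made for them only; others in the source may bear on it.

Measured compounds:
compound 1 `Cn1cccc1-c1nc2cc(NC(=O)CCCl)ccc2[nH]1` — > 50000 nM
compound 2 `CCN1CCN(CCC(=O)Nc2ccc3[nH]c(-c4ccc(Br)cc4)nc3c2)CC1` — 27400 nM
compound 3 `CCN1CCN(CCC(=O)Nc2ccc3[nH]c(-c4ccc(C)cc4)nc3c2)CC1` — 14600 nM

Of the compounds shown here, three have been measured in a functional assay on HepG2 cells (Homo sapiens) for cytotoxicity, read by MTT assay, with a stated time of 72 h; on this read-out higher numbers stand for weaker inhibition and lower numbers for stronger inhibition. Compound 1 reaches only a limit, (the limit of > 50000 nM in this assay, at which 1 of the 3 values shown sits), and not a number. Compound 3 stands next to compound 2, and the step of a 1.9-fold lower number from compound 2 to compound 3 (0.27 log units; within the scatter) stays within the scatter. Compound 4 `Cc1ccc(-c2nc3cc(NC(=O)CN4CCCCC4)ccc3[nH]2)cc1` is compound 3 with piperidin-1-yl in place of (4-ethylpiperazin-1-yl)methyl on a saturated chain carbon bound to a carbonyl carbon. No measured step touches this part of the molecule: the one step shown, a 1.9-fold lower number from compound 2 to compound 3 (0.27 log units; within the scatter), is a change on an aromatic carbon, and it was small. No shift beyond the scatter is therefore expected in this assay. The expected step is a 1.1-fold higher number from compound 3 to compound 4 (0.04 log units; within the scatter). Compound 4 is estimated at 16000 nM, within a range from 5000 nM to 50000 nM.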

Compound 4, half-maximal inhibitory concentration: > 50000 nM
Compound 4 gave a limit, no number; the forecaster's own chance of this, stated with the estimate: 25%; middle value at least 3.1-fold (0.49 log units) away from the limit.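

Putting piperidin-1-yl in place of (4-ethylpiperazin-1-yl)methyl on a saturated chain carbon bound to a carbonyl carbon gives an at least 3.4-fold higher number from compound 3 to compound 4 (0.53 log units; beyond the scatter) in this assay. Unlike the earlier change on an aromatic carbon, this change moves the result beyond the scatter. The full size of the step stays unknown, as compound 4 reaches only a limit of the assay: the limit of > 50000 nM in this assay, at which 2 of the 4 values shown sit.

The ring and the chain change together here. From the compounds shown here alone, it remains open whether a morpholine on the same shorter chain, or piperidin-1-yl on the longer chain, would give a measurable number.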